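Half-life in liver cytosol along an amine substituent swap

This account rests on a few compounds, and the source may have more. Where it says the series, first, only, none or still open, it means among the compounds named here.

Measured so far:
compound 1 `Cn1cc(-c2ccc3nnc(Sc4ccc5ncc(N6CCC(N)C6)cc5c4)n3c2)cn1`: > 8.33 h
compound 2 `Cn1cc(-c2ccc3nnc(Sc4ccc5ncc(NCC6CCOC6)cc5c4)n3c2)cn1`: 2.15 h

In an ADME assay on cytosol from liver (strain IGS SD) for pharmacokinetics, with aldehyde oxidase 1 (Rattus norvegicus) as the target, read by LC-MS, with a stated time of 120 min, tested at 1 uM (on this read-out higher numbers stand for a longer-lived compound and lower numbers for a shorter-lived compound), compound 1 gives > 8.33 h, which is a limit of the assay rather than a number (the limit of > 8.33 h in this assay, at which 1 of the 2 values shown sits). In this assay, among the measured compounds shown here, compound 2 gives 2.15 h, the only actual number so far. For the measured compounds named here, the one measured step, an at least 3.8-fold lower number from compound 1 to compound 2 (0.58 log units; beyond the scatter), shows that exchanging the group on the aromatic carbon shortens the half-life by a modest amount, beyond the scatter.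

Compound 3 `Cn1cc(-c2ccc3nnc(Sc4ccc5ncc(NC6CCOCC6)cc5c4)n3c2)cn1` differs from compound 2 by oxan-4-yl in place of (oxolan-3-yl)methyl on a nitrogen on an aromatic ring. This is a different kind of change from the measured step: the amine nitrogen stays, and the group on it keeps its size and its single acceptor while the ring grows and the linking carbon is folded into it. The measured step does not speak to this rearrangement, so no change beyond the scatter is expected in this assay, with some room for a modest move either way. For compound 3 the half-life in this assay is estimated at 2.5 h, between 1 h and 6 h, which means an expected step of a 1.2-fold higher number from compound 2 to compound 3 (0.07 log units; within the scatter).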

Compound 3, half-life: 7.18 h
Compound 3: middle estimate off by 2.9-fold (0.46 log units), on the low side; measured number above the stated range.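

The exchange on this nitrogen gives a 3.3-fold higher number from compound 2 to compound 3 (0.52 log units; beyond the scatter) in this assay even though oxan-4-yl and (oxolan-3-yl)methyl carry the same heavy atoms and the same hydrogen-bond counts. The half-life in this series therefore depends on how the group on the amine nitrogen is assembled, and not only on which kind of amine sits on the aromatic carbon, which was all that the earlier step could suggest. The other new step, an at least 1.1-fold lower number from compound 1 to compound 3 (0.06 log units; that floor lies within the scatter) against the 3-aminopyrrolidin-1-yl compound, gives only a floor, so the two compounds cannot be placed in order. Compound 1 stands at a limit of the assay and not at a number: the limit of > 8.33 h in this assay, at which 1 of the 3 values shown sits.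

Ring size and the position of the linking carbon change together in the swap from (oxolan-3-yl)methyl to oxan-4-yl, and the compounds shown do not separate the two. An (oxan-4-yl)methyl group on the same nitrogen would part them, while a piperidin-4-yl group would show whether the ring oxygen can give way to a ring amine without loss of half-life.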